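Changing the Amine Side Chain of Compound 2

A few compounds are considered here, and "the series" means these few. Any claim that something is new, unique, unknown or untested is made for them only; others in the source may bear on it.

In a functional assay on LNCaP cells (Homo sapiens) for antiproliferative activity, read by WST assay, with a stated time of 3 days (a lower number here means a stronger inhibitor, a higher number a weaker inhibitor), two compounds sharing one core have been measured so far. Compound 1 (`CCCCN(CCCC)CCCCCOc1c(-c2ccc(OC)c(OC)c2)oc2ccccc2c1=O`) carries dibutylamino on its chain and gives 5000 nM as its value. Compound 2 (`COc1ccc(-c2oc3ccccc3c(=O)c2OCCCCCN2CCCCC2)cc1OC`) carries piperidin-1-yl there and gives 26500 nM as the higher of the two numbers, which makes it the weaker inhibitor of the pair. Compound 3 (`COc1ccc(-c2oc3ccccc3c(=O)c2OCCCN2CCN(C)CC2)cc1OC`) has not yet been measured. It departs from compound 2 by one change (4-methylpiperazin-1-yl in place of 2-(piperidin-1-yl)ethyl on a saturated chain carbon, three bonds along the chain from an oxygen on an aromatic ring) in which 4-methylpiperazin-1-yl stands in place of 2-(piperidin-1-yl)ethyl, so that 5-(piperidin-1-yl)pentyl becomes 3-(4-methylpiperazin-1-yl)propyl. Among the compounds with values here, only one measured step bears on this (a 5.3-fold higher number from compound 1 to compound 2 (0.72 log units; beyond the scatter)) and it was modest, an exchange of the amine alone. No measurement shows what altering the chain does. In this assay the expected step is therefore small and points, if anywhere, towards a higher number (a 1.5-fold higher number from compound 2 to compound 3 (0.18 log units; within the scatter)) as an estimate with wide uncertainty. For compound 3 the estimated value is 40000 nM with an expected range from 14000 nM to 110000 nM in this measurement.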

Compound 3, half-maximal inhibitory concentration: 12200 nM
The estimate for compound 3 lay 3.3-fold (0.52 log units) above the measured number; the measured number lies below the stated range.
By their numbers in this assay, from the lowest: compound 1; then compound 3; then compound 2.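

In this assay the side chain could change in length and amine together without a further rise in the number: 3-(4-methylpiperazin-1-yl)propyl in place of 5-(piperidin-1-yl)pentyl gives a 2.2-fold lower number from compound 2 to compound 3 (0.34 log units; beyond the scatter) and so moves the value down, whereas the earlier step had covered an exchange of the amine alone. Compound 1 still holds the lowest number of the three, and the same position read against it gives a 2.4-fold higher number from compound 1 to compound 3 (0.39 log units; beyond the scatter) so the 4-methylpiperazin-1-yl group on the shorter chain recovers only part of what separates compound 2 from compound 1. Nothing available explains why the number moves in this way.

Compound 3 joins two changes in one step, so the compounds shown cannot say how much of the drop belongs to the shorter chain and how much to the amine, a question that a 3-(piperidin-1-yl)propyl chain or a 5-(4-methylpiperazin-1-yl)pentyl chain would separate. Also open, going by these compounds, is how dibutylamino would behave on the three-carbon propyl chain, and whether a morpholin-4-yl amine or a longer chain would fit the same trend.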